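Hexylamino to Cyclohexylamino on a Nitrile-Bearing Core

The source may hold more compounds than are shown below. What is called first, only, known or untested is meant among the compounds shown, and "the series" means these compounds.

Of the compounds shown here, two sharing one core have been measured in an in vitro functional assay on cells for antagonist activity at metabotropic glutamate receptor 1 (Rattus norvegicus), read by inositol phosphate accumulation; a higher number here means a weaker inhibitor, a lower number a stronger inhibitor. Compound 1 `CC1(C)CC(=O)c2cc(C#N)c(SCc3ccccc3)nc2C1` carries a benzylthio group and gives 4800 nM. Compound 2 `CCCCCCNc1nc2c(cc1C#N)C(=O)CC(C)(C)C2` carries a hexylamino group in the same position and gives 2600 nM. The two numbers lie within the usual scatter of each other, so compound 2 and compound 1 cannot be told apart on this assay; neither stands out.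

Compound 3 `CC1(C)CC(=O)c2cc(C#N)c(NC3CCCCC3)nc2C1` has not yet been measured. It differs from compound 2 in one place: cyclohexyl in place of hexyl on a nitrogen on an aromatic ring. Among the measured compounds shown here, no step between measured compounds of the same kind is available here, and the two values on hand tell nothing about how such a change might act.

The expected step from compound 2 to compound 3 in this assay is therefore small, a 1.3-fold lower number from compound 2 to compound 3 (0.11 log units; within the scatter), and not beyond the scatter in either direction. Compound 3 is estimated at 2000 nM, with a range from 600 nM to 7000 nM.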

Compound 3, half-maximal inhibitory concentration: 4000 nM
For compound 3 the middle estimate is 2.0-fold (0.30 log units) below the measured one; the range from low to high includes it.
By their numbers in this assay, from the lowest: compounds 2, 3 and 1 (each within the scatter of the next).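

In this assay the change from hexylamino to cyclohexylamino gives a 1.5-fold higher number from compound 2 to compound 3 (0.19 log units; within the scatter) and so stays within the scatter; the open chain and the ring, each of six carbons, cannot be told apart on the nitrogen on the aromatic ring. Among the compounds shown here, this is the first step that can be read as a single change, and it shows that at this position a six-membered ring can stand in place of a hexyl chain with no difference that this measurement can resolve. Nothing on hand accounts for why the two groups read alike.

With all three compounds lying within the scatter of their neighbours, no group shown here has yet moved the number clearly, so it remains open whether any substituent on this nitrogen can do so, for instance a butyl chain, a benzyl group or a cyclohexyl ring bearing a hydroxyl. Also open, going by these compounds, is whether the nitrile matters at all, which a carboxylic acid or an amide in its place would begin to test.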